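The source may hold more compounds than are shown below. What is called first, only, known or untested is meant among the compounds shown, and "the series" means these compounds.

The measured compounds in a functional assay on HL-60 cells (Homo sapiens) for antiproliferative activity, read by sulforhodamine B assay, with a stated time of 72 h; on this read-out lower numbers stand for stronger inhibition and higher numbers for weaker inhibition:
compound 1, `NC(=S)N/N=C/c1ccc2ccccc2n1`: > 100000 nM (a limit of the assay)
compound 2, `COc1ccc(C)cc1NC(=S)N/N=C/c1ccc2ccccc2n1`: > 100000 nM (a limit of the assay)
compound 3, `S=C(N/N=C/c1ccc2ccccc2n1)Nc1cccc(Br)c1`: 53800 nM

The three compounds share one core and differ only in what sits on an amide-type nitrogen. In this assay compound 1 gives > 100000 nM, which is a limit of the assay and not a number. Compound 2 likewise stops at a limit, > 100000 nM. Compound 3 gives 53800 nM. For the measured compounds named here, the single step that joins two of these with one structural change is an at least 1.8-fold lower number from compound 1 to compound 3 (0.26 log units; that floor lies within the scatter). Compound 1 therefore stands at the limit, and the limit of > 100000 nM in this assay, at which 2 of the 3 values shown sit, describes where two of the three values sit.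

Compound 4, `S=C(N/N=C/c1ccc2ccccc2n1)Nc1ccccc1`, has not yet been measured in this assay. It differs from compound 1 by phenyl in place of hydrogen on an amide-type nitrogen. The step from compound 1 to compound 3 is the only one that bears on this change, and it does not clear the scatter. A phenyl without bromine is expected to move the number no further than that, if at all, and a lower number is only a weak expectation. Compound 4 is therefore expected to give about 90000 nM, between 35000 nM and 250000 nM. That estimate amounts to an at least 1.1-fold lower number from compound 1 to compound 4 (0.04 log units; that floor lies within the scatter). With compound 1 sitting at the limit > 100000 nM, a report of only a limit for compound 4 is also considered quite possible.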

Compound 4, half-maximal inhibitory concentration: 9130 nM
Compound 4: the middle estimate sits 9.9-fold (0.99 log units) above what was measured, outside the stated range (below it).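

In this assay, phenyl in place of hydrogen on an amide-type nitrogen gives an at least 10-fold lower number from compound 1 to compound 4 (1.03 log units; beyond the scatter), so this nitrogen does respond to substitution, which an at least 1.8-fold lower number from compound 1 to compound 3 (0.26 log units; that floor lies within the scatter) had not shown. The bromine also matters, since hydrogen in place of bromo on an aromatic carbon gives a 5.9-fold lower number from compound 3 to compound 4 (0.77 log units; beyond the scatter), so most of the gain appears with the unsubstituted phenyl and bromo gives a good part of it back. Compound 1 is only a limit, > 100000 nM, so the first step is a floor and its full size stays unknown, and that limit is a common stopping point here: the limit of > 100000 nM in this assay, at which 2 of the 4 values shown sit.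

The compounds shown leave open how a fluoro, a hydroxyl or an amine on the phenyl would compare with the hydrogen of compound 4, and so whether the loss seen with bromo extends to other groups. Also open, on these data alone, is whether a benzyl or a longer chain on the same amide-type nitrogen would serve as well as phenyl, and whether the gain holds in other cells.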